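From Methoxy to Chloro on Compound 2

A few compounds are considered here, and "the series" means these few. Any claim that something is new, unique, unknown or untested is made for them only; others in the source may bear on it.

Measured so far in a functional assay on B16 cells (Mus musculus) for inhibition; on this read-out lower numbers stand for stronger inhibition and higher numbers for weaker inhibition
- compound 1 (`Cc1cccc(CNC(=O)/C=C/c2ccc(O)c(O)c2)c1`) at 3000 nM
- compound 2 (`COc1ccccc1CNC(=O)/C=C/c1ccc(O)c(O)c1`) at 7000 nM

Compound 2 holds the higher of these two numbers, which makes it the weaker inhibitor, and its gap to compound 1 lies beyond the usual scatter. Compound 3 (`O=C(/C=C/c1ccc(O)c(O)c1)NCc1ccccc1Cl`) has chloro in place of methoxy on an aromatic carbon, ortho to a large group (chloro in place of methoxy on an aromatic carbon). Among the compounds with values here, no measured pair shows this swap alone, so the guide is thin. In this assay compound 1, which lacks the methoxy, gives 3000 nM (the lower number). A small move to a lower number is expected, a 1.8-fold lower number from compound 2 to compound 3 (0.24 log units; within the scatter) (possibly no more than the scatter). For compound 3 the estimated value is 4000 nM (range 1500 nM to 10000 nM).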

Compound 3, half-maximal inhibitory concentration: 6500 nM
Beside the measured number, compound 3's estimate is 1.6-fold (0.21 log units) below it; the range from low to high includes it.
By their numbers in this assay, from the lowest: compound 1; then compounds 3 and 2 (each within the scatter of the next).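

In this assay chloro in place of methoxy on an aromatic carbon, ortho to a large group, gives a 1.1-fold lower number from compound 2 to compound 3 (0.03 log units; within the scatter) and so leaves the number unchanged within the scatter; at this position, the two groups cannot be told apart. Placing 2-chlorophenyl where compound 1 has 3-methylphenyl gives a 2.2-fold higher number from compound 1 to compound 3 (0.34 log units; beyond the scatter) and is a modest step beyond the scatter. No measurement here explains these results. Still open, from the compounds shown here alone, is whether an amine or a carboxylic acid at this position would shift the number.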